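This account rests on a few compounds, and the source may have more. Where it says the series, first, only, none or still open, it means among the compounds named here.

In an ADME assay on a cell-free system (plasma, Homo sapiens) for metabolic stability, read by LC-MS (a lower number here means that the compound disappears faster, a higher number that the compound lasts longer), compound 1 `CC1=C(CC(=O)OCCOc2ccc3oc(=O)ccc3c2)c2cc(F)ccc2/C1=C\c1ccc([S+](C)[O-])cc1` gives > 4 h, which is a limit of the assay and not a number. Compound 2 `CC(C)Cc1ccc(C(C)C(=O)OCCOc2ccc3oc(=O)ccc3c2)cc1` also gives only a limit, > 4 h. Compound 3 `COc1ccc2c(c1)c(CC(=O)OCCOc1ccc3ccc(=O)oc3c1)c(C)n2C(=O)c1ccc(Cl)cc1` likewise gives only a limit, > 4 h. Compound 1 therefore has no exact half-life to set against the others, and the three readings share one mark: the limit of > 4 h in this assay, at which 3 of the 3 values shown sit. Within the data shown here, no step between measured compounds is available.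

Compound 4 `CC1=C(CC(=O)OCCOc2ccc3ccc(=O)oc3c2)c2cc(F)ccc2/C1=C\c1ccc([S+](C)[O-])cc1` has the same atoms as compound 1, joined differently: a group of 11 heavy atoms (9 carbon, 2 oxygen; one six-membered aromatic ring of carbon only, one six-membered aromatic ring with 1 hetero atom) in place of a group of 11 heavy atoms (9 carbon, 2 oxygen; one six-membered aromatic ring of carbon only, one six-membered aromatic ring with 1 hetero atom), on an oxygen on a saturated carbon. The change lies on an oxygen on a saturated carbon. The expected step, a step that the limit leaves unreadable from compound 1 to compound 4, is estimated to stay within the usual scatter of this assay, with no direction foreseen. That expectation rests on compound 1, whose reading is the limit > 4 h. For compound 4 the estimated half-life is 6 h, with an expected range from 3 h to 12 h.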

Compound 4, half-life: > 4 h
Compound 4 was reported as a limit (the forecaster's own chance of this, stated with the estimate: 80%); the middle value does not contradict the limit.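

In this assay compound 4 gives > 4 h, which is a limit and not a number. Among these compounds, compound 1 also reads only as a limit, so no step between compound 1 and compound 4 can be read. The compounds shown leave open how long any of them actually lasts, since all share one mark: the limit of > 4 h in this assay, at which 4 of the 4 values shown sit.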